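The compounds below may be only part of what the source reports. "The series", "measured", "known", "first", "only" and "open" are said of these compounds alone.

Compound 1, `O=C(NC1CCN(c2ncnc3[nH]ncc23)CC1)c1ccc(Br)cc1`: 16400 nM
Compound 2, `O=C(NC1CCN(c2ncnc3[nH]ncc23)CC1)c1cccc(Cl)c1Cl`: 4170 nM

In an assay on isolated protein for inhibition of serine/threonine-protein kinase PAK 1 (Homo sapiens), read by ADP-Glo, with a stated time of 40 min (on this read-out higher numbers stand for weaker inhibition and lower numbers for stronger inhibition), compound 2 stands lowest of the two numbers, and compound 1 sits higher by a 3.9-fold lower number from compound 1 to compound 2 (0.59 log units; beyond the scatter). Compound 3, `O=C(Nc1ccc(F)cc1F)NC1CCN(c2ncnc3[nH]ncc23)CC1`, follows from compound 2 by one change, ((2,4-difluorophenyl)amino in place of 2,3-dichlorophenyl on a carbonyl carbon). For the measured compounds named here, the only measured step that bears on it, a 3.9-fold lower number from compound 1 to compound 2 (0.59 log units; beyond the scatter), also swaps the group on the carbonyl carbon, but no step covers an amino entering at that place, so the direction stays open. Compound 3 is expected near compound 2, a step of a 1.2-fold higher number from compound 2 to compound 3 (0.08 log units; within the scatter), with an estimate of 5000 nM ranging from 1500 nM to 17000 nM.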

Compound 3, half-maximal inhibitory concentration: 1140 nM
Beside the measured number, compound 3's estimate is 4.4-fold (0.64 log units) above it; the measured number lies below the stated range.
By their numbers in this assay, from the lowest: compound 3; then compound 2; then compound 1.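

At this place on a carbonyl carbon, the ring need not be attached directly: in this assay, (2,4-difluorophenyl)amino gives a 3.7-fold lower number from compound 2 to compound 3 (0.56 log units; beyond the scatter) and a 14-fold lower number from compound 1 to compound 3 (1.16 log units; beyond the scatter). The urea-type link, with its added hydrogen-bond donor, is therefore tolerated here and accompanies the lowest number of the three. Nothing measured here accounts for this gain.

The amino group and the change in ring halogens enter together, so their contributions remain unseparated. A (2,3-dichlorophenyl)amino group or an unsubstituted phenylamino group would divide them.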